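Sulfamoyl in Place of Hydroxy: Expectation for Compound 4

This account rests on a few compounds, and the source may have more. Where it says the series, first, only, none or still open, it means among the compounds named here.

Of the compounds shown here, three have been measured in a functional assay on HCT-116 cells (Homo sapiens) for antiproliferative activity, read by MTT assay, with a stated time of 72 h; on this read-out lower numbers stand for stronger inhibition of growth and higher numbers for weaker inhibition of growth. Compound 1 `CCn1nc(-c2ccnc(Nc3cccc(S(N)(=O)=O)c3)n2)c2ccccc21` gives 9010 nM, compound 2 `CCn1nc(-c2ccnc(Nc3cccc(O)c3)n2)c2ccccc21` gives 36600 nM, and compound 3 `CCCn1nc(-c2ccnc(Nc3ccc(O)cc3)n2)c2ccccc21` gives 5450 nM. Compound 2 and compound 1 differ in one place, (sulfamoyl in place of hydroxy on an aromatic carbon), and that step gave a 4.1-fold lower number from compound 2 to compound 1 (0.61 log units; beyond the scatter). The difference between the cores of compound 3 and compound 2 is not broken down here. Compound 4 `CCCn1nc(-c2ccnc(Nc3ccc(S(N)(=O)=O)cc3)n2)c2ccccc21` is not yet measured; it stands to compound 3 as compound 1 stands to compound 2, (sulfamoyl in place of hydroxy on an aromatic carbon), the same kind of change, though in compound 4 the new group is para to a large group whereas in compound 1 it is meta to a large group. A step of similar size is expected for compound 4, a 3.0-fold lower number from compound 3 to compound 4 (0.48 log units; beyond the scatter), because a 4.1-fold lower number from compound 2 to compound 1 (0.61 log units; beyond the scatter) lies beyond the scatter. Compound 4 is therefore estimated at 1800 nM in this assay, with a likely range from 600 nM to 5500 nM.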

Compound 4, concentration for 50% growth inhibition: 6740 nM
For compound 4 the middle estimate is 3.7-fold (0.57 log units) below the measured one, and the stated range ends below it.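

In this assay, sulfamoyl in place of hydroxy on an aromatic carbon gave a 1.2-fold higher number from compound 3 to compound 4 (0.09 log units; within the scatter), so the step seen on the core of compound 2 did not carry over to the core of compound 3. The change therefore cannot be treated as transferable between these two cores: the same change on two cores in this assay, a 4.1-fold lower number (0.61 log units; beyond the scatter) from compound 2 to compound 1 and a 1.2-fold higher number (0.09 log units; within the scatter) from compound 3 to compound 4, 5.0-fold (0.70 log units) apart, beyond the scatter of two such steps. This does not show what sets the two steps apart, since the pairs differ in their cores and also in where the group sits, and two pairs cannot separate these differences.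

Still open, from the compounds shown here alone, is how an amine or a carboxylic acid in place of hydroxy would behave on either core. Also open, going by these compounds, is whether the same step would recur with sulfamoyl and hydroxy compared at the same place on both cores.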